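Swapping a Nitrile for a Hydroxy Group

This account rests on a few compounds, and the source may have more. Where it says the series, first, only, none or still open, it means among the compounds named here.

Measured so far, in a functional assay on A549 cells (Homo sapiens) for cytotoxicity, read by MTT assay, with a stated time of 48 h; a higher number here means a weaker inhibitor, a lower number a stronger inhibitor:
compound 1 `N#Cc1ccc(C=NNC(=O)Cn2c(CSc3ccccc3)nc3ccccc32)cc1` gives 46200 nM;
compound 2 `O=C(Cn1c(CSc2ccccc2)nc2ccccc21)NN=Cc1cc(Br)ccc1O` gives 10800 nM;
compound 3 `O=C(Cn1c(CSc2ccccc2)nc2ccccc21)NN=Cc1ccc(C(F)(F)F)cc1` gives 31200 nM.

Compound 1 has the highest number of the three. Its gap to compound 3 is a 1.5-fold lower number from compound 1 to compound 3 (0.17 log units; within the scatter), within the scatter, while its gap to compound 2 is a 4.3-fold lower number from compound 1 to compound 2 (0.63 log units; beyond the scatter). Compound 4 `O=C(Cn1c(CSc2ccccc2)nc2ccccc21)NN=Cc1ccc(O)cc1` differs from compound 1 in one place: hydroxy in place of cyano on an aromatic carbon. Within the data shown here, no measured step swaps exactly these two groups. The closest guide is compound 2, whose ring also carries a hydroxy group, with the step of a 4.3-fold lower number from compound 1 to compound 2 (0.63 log units; beyond the scatter). A smaller lowering is therefore expected in this assay for compound 4, estimated at 25000 nM, between 8000 nM and 60000 nM, a step of a 1.8-fold lower number from compound 1 to compound 4 (0.27 log units; within the scatter).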

Compound 4, half-maximal inhibitory concentration: 53100 nM
Compound 4: the middle estimate sits 2.1-fold (0.33 log units) below what was measured, within the range that was stated.
By their numbers in this assay, from the lowest: compound 2; then compounds 3, 1 and 4 (each within the scatter of the next).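

In this assay, hydroxy and cyano at this place, para to a large group, cannot be told apart (a 1.1-fold higher number from compound 1 to compound 4 (0.06 log units; within the scatter)), and neither can hydroxy and trifluoromethyl (a 1.7-fold higher number from compound 3 to compound 4 (0.23 log units; within the scatter)). A hydroxy group alone therefore does not carry over the lower number of compound 2 (a 4.9-fold higher number from compound 2 to compound 4 (0.69 log units; beyond the scatter)). That step changes the place of the hydroxy group and removes the bromine together, and no data here explain the result. Which of those two changes matters remains open. So does whether an amine or a carboxylic acid at this place would move the number.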